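From Fluoro to Trifluoromethyl on the Pendant Phenyl Ring

This account rests on a few compounds, and the source may have more. Where it says the series, first, only, none or still open, it means among the compounds named here.

Three compounds share one core and differ only in the group on an aromatic carbon of the outer phenyl ring. Compound 1 `COc1cc2c(Oc3ccc(NC(=O)c4cc(-c5ccccc5)ccn4)cc3F)ccnc2cc1OCCCN1CCCC1` carries hydrogen there; in a functional assay on MKN-45 cells (Homo sapiens) for cytotoxicity, read by MTT assay, with a stated time of 72 h (on this read-out higher numbers stand for weaker inhibition and lower numbers for stronger inhibition), compound 1 gives 210 nM. Compound 2 `COc1cc2c(Oc3ccc(NC(=O)c4cc(-c5ccc(C)cc5)ccn4)cc3F)ccnc2cc1OCCCN1CCCC1` carries methyl, and in this assay compound 2 gives 440 nM. Compound 3 `COc1cc2c(Oc3ccc(NC(=O)c4cc(-c5ccc(F)cc5)ccn4)cc3F)ccnc2cc1OCCCN1CCCC1` carries fluoro; in this assay compound 3 gives 350 nM. On the numbers themselves compound 3 stands second highest of the three, yet its steps to both neighbours remain within the scatter: a 1.7-fold higher number from compound 1 to compound 3 (0.22 log units; within the scatter) and a 1.3-fold lower number from compound 2 to compound 3 (0.10 log units; within the scatter). Only the exchange of hydrogen for methyl reaches beyond it, a 2.1-fold higher number from compound 1 to compound 2 (0.32 log units; beyond the scatter).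

Compound 4 `COc1cc2c(Oc3ccc(NC(=O)c4cc(-c5ccc(C(F)(F)F)cc5)ccn4)cc3F)ccnc2cc1OCCCN1CCCC1` is not yet measured. It differs from compound 3 by trifluoromethyl in place of fluoro on an aromatic carbon. Among the measured compounds shown here, the steps that bear on it are the three exchanges at this same place: both methyl and fluoro gave higher numbers than hydrogen, and the one step beyond the scatter was the move to methyl. Exchanging fluoro, one heavy atom, for trifluoromethyl, four heavy atoms, is therefore expected to raise the number modestly, a 1.4-fold higher number from compound 3 to compound 4 (0.15 log units; within the scatter). Compound 4 is estimated at 500 nM in this assay, within 250 nM to 1000 nM.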

Compound 4, half-maximal inhibitory concentration: 260 nM
For compound 4 the middle estimate is 1.9-fold (0.28 log units) above the measured one; the range from low to high includes it.
By their numbers in this assay, from the lowest: compounds 1, 4, 3 and 2 (each within the scatter of the next, the first and the last beyond it).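

Trifluoromethyl has four heavy atoms against the single one of fluoro, yet exchanging one for the other at this place in this assay stays within the scatter (a 1.3-fold lower number from compound 3 to compound 4 (0.13 log units; within the scatter)). Among the compounds shown here, the same is true when trifluoromethyl is set against the other two groups (a 1.7-fold lower number from compound 2 to compound 4 (0.23 log units; within the scatter)) and (a 1.2-fold higher number from compound 1 to compound 4 (0.09 log units; within the scatter)), so this place on the outer phenyl ring accepts the larger group with no step that can be told apart from repeat-measurement noise. For the compounds shown here, compound 1 and compound 2 remain the only pair beyond the scatter, and compound 4 goes against any reading of that gap as a simple rule that a larger group at this place gives a higher number.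

These four compounds leave open whether an amine, a carboxylic acid or a longer chain at this place would produce a step beyond the scatter, and whether the same groups would behave alike elsewhere on the ring. Nothing measured here gives a reason why these four numbers lie so close together.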